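Side-chain ring swaps on a shared core

The compounds below may be only part of what the source reports. "The series", "measured", "known", "first", "only" and "open" are said of these compounds alone.

In a functional assay on RAW264.7 cells (Mus musculus) for inhibition, read by Griess assay, with stated times of 2 h and 18 h (a higher number here means a weaker inhibitor, a lower number a stronger inhibitor), compound 1 `CC(=O)O[C@@H]1CC[C@]2(C)C(CCc3ccoc3)=C(C)C(=O)[C@@H](O)[C@H]2C1(C)C` gives 22500 nM and compound 2 `CCOC1CC(O)(CCC2=C(C)C(=O)[C@@H](O)[C@H]3C(C)(C)[C@H](OC(C)=O)CC[C@]23C)CO1` gives 30400 nM so compound 2 stands level with compound 1 within the scatter. Compound 3 `CC(=O)O[C@@H]1CC[C@]2(C)C(CCC3=CCOC3=O)=C(C)C(=O)[C@@H](O)[C@H]2C1(C)C` differs from compound 2 by one change a group of 6 heavy atoms (4 carbon, 2 oxygen; one five-membered non-aromatic ring with 1 hetero atom) in place of a group of 9 heavy atoms (6 carbon, 3 oxygen; one five-membered non-aromatic ring with 1 hetero atom), on a saturated chain carbon, two bonds along the chain from a double-bonded ring carbon at the same chain carbon. Within the data shown here, only one measured step bears on this place: exchanging furan-3-yl for 5-ethoxy-3-hydroxyoxolan-3-yl gave a 1.4-fold higher number from compound 1 to compound 2 (0.13 log units; within the scatter) and so stayed within the scatter. Among the measured compounds shown here, no shift beyond the scatter is therefore expected, and the expected step is a 1.2-fold lower number from compound 2 to compound 3 (0.08 log units; within the scatter) with only this single precedent behind it. Compound 3 is estimated at 25000 nM (range 10000 nM to 60000 nM).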

Compound 3, half-maximal inhibitory concentration: > 50000 nM
Compound 3: no number, only a limit; the forecaster's own chance of this, stated with the estimate: 15%; middle value at least 2.0-fold (0.30 log units) away from the limit.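

Compound 3 gives > 50000 nM in this assay, which is a limit and not a number. Ring swaps at this place on the saturated chain carbon are therefore not all silent: the furan-3-yl exchange yields an at least 2.2-fold higher number from compound 1 to compound 3 (0.34 log units; beyond the scatter), the first step here beyond the scatter. Against 5-ethoxy-3-hydroxyoxolan-3-yl, the same group gives an at least 1.6-fold higher number from compound 2 to compound 3 (0.21 log units; that floor lies within the scatter), so that comparison shows no firm shift.

As far as these compounds go, the true size of both steps remains open. So does the outcome of an amine, a carboxylic acid or a longer chain at this place.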